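Chain to ring at the aromatic nitrogen: compound 4

This account rests on a few compounds, and the source may have more. Where it says the series, first, only, none or still open, it means among the compounds named here.

Measured compounds in a functional assay on MCF7 cells (Homo sapiens) for cytotoxicity; on this read-out lower numbers stand for an effect already at smaller amounts and higher numbers for an effect only at larger amounts of compound:
Compound 1 `COc1cc(Cc2nc3c(N)ncnc3n2CC(C)CO)cc(OC)c1OC` gives 49100000 nM.
Compound 2 `CCCCCn1c(Cc2cc(OC)c(OC)c(OC)c2)nc2c(N)nc(F)nc21` gives 286000000 nM.
Compound 3 `CC#CCCn1c(Cc2cc(OC)c(OC)c(OC)c2)nc2c(N)nc(F)nc21` gives 95500000 nM.

Compound 2 carries the highest number of the three, beyond the scatter from both others. Among the measured compounds shown here, the one step recorded from it, a 3.0-fold lower number from compound 2 to compound 3 (0.48 log units; beyond the scatter), alters the chain two bonds along from the aromatic nitrogen. Compound 4 `COc1cc(Cc2nc3c(N)nc(F)nc3n2CC2CCC2)cc(OC)c1OC` differs from compound 2 by cyclobutyl in place of butyl on a saturated chain carbon bound to an aromatic nitrogen. For the measured compounds named here, no measured pair closes a chain into a ring, so the step to compound 3 bears on compound 4 only loosely; a modest lowering at most is expected, with none beyond the scatter also possible. For compound 4 the expected step is a 1.9-fold lower number from compound 2 to compound 4 (0.28 log units; within the scatter). Compound 4 is estimated at 150000000 nM, in the range 50000000 nM to 400000000 nM.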

Compound 4, half-maximal effective concentration: 109000000 nM
Compound 4: the middle estimate sits 1.4-fold (0.14 log units) above what was measured; the range from low to high includes it.
By their numbers in this assay, from the lowest: compounds 1, 3 and 4 (each within the scatter of the next, the first and the last beyond it); then compound 2.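

In this assay, among the compounds shown here, replacing the open chain with a ring at this position moves the number beyond the scatter (butyl to cyclobutyl on a saturated chain carbon bound to an aromatic nitrogen: a 2.6-fold lower number from compound 2 to compound 4 (0.42 log units; beyond the scatter)) and gives the first ring step. The ring and the but-2-yn-1-yl chain cannot be told apart here (a 1.1-fold higher number from compound 3 to compound 4 (0.06 log units; within the scatter)) although each differs from the pentyl of compound 2 beyond the scatter. Nothing available accounts for either step.

Open, on these data alone, is whether cyclopropyl or cyclohexyl at this position follows cyclobutyl. Also open, as far as these compounds go, is how a chain ending in an amine or a carboxylic acid compares.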